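A few compounds are considered here, and "the series" means these few. Any claim that something is new, unique, unknown or untested is made for them only; others in the source may bear on it.

Compound 3 `CCC1=C(O)c2c(oc(-c3ccc(C)c(C)c3)cc2=O)C(CC)(CC)C1=O` has the lowest of the three numbers seen so far in a functional assay on KBVIN cells (Homo sapiens) for antiproliferative activity, read by sulforhodamine B assay, with a stated time of 3 days (on this read-out higher numbers stand for an effect only at larger amounts of compound and lower numbers for an effect already at smaller amounts), giving 0.71 uM. Its closest neighbour is compound 1 `CCC1=C(O)c2c(oc(-c3ccc(C(C)C)cc3)cc2=O)C(CC)(CC)C1=O`, which in this assay gives 1.08 uM, and the gap between them, a 1.5-fold lower number from compound 1 to compound 3 (0.18 log units; within the scatter), is within the scatter, so the two cannot be ranked. Compound 2 `CCOc1ccc(-c2cc(=O)c3c(o2)C(CC)(CC)C(=O)C(CC)=C3O)cc1` gives 7.54 uM, and the step of an 11-fold lower number from compound 2 to compound 3 (1.03 log units; beyond the scatter) is well beyond the scatter.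

Compound 4 `CCC1=C(O)c2c(oc(-c3ccc(O)c(C)c3C)cc2=O)C(CC)(CC)C1=O` differs from compound 3 by 4-hydroxy-2,3-dimethylphenyl in place of 3,4-dimethylphenyl on an aromatic carbon. The measured steps that bear on this are the two that involve an oxygen-bearing substituent on the pendant ring: a 7.0-fold higher number from compound 1 to compound 2 (0.84 log units; beyond the scatter) and an 11-fold lower number from compound 2 to compound 3 (1.03 log units; beyond the scatter). Both show that placing an oxygen on that ring went with clearly higher numbers, while the carbon-only groups of compound 1 and compound 3 stayed close together. A hydroxy group is not an ethoxy group, and the two methyls also shift, so the carry-over is uncertain. A modest rise in the number is therefore expected, a 2.8-fold higher number from compound 3 to compound 4 (0.45 log units; beyond the scatter), with compound 4 estimated at 2 uM, within a range of 0.6 uM to 6.5 uM.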

Compound 4, concentration for half-maximal effect: 2.75 uM
Beside the measured number, compound 4's estimate is 1.4-fold (0.14 log units) below it; the range from low to high includes it.
By their numbers in this assay, from the lowest: compounds 3 and 1 (each within the scatter of the next); then compound 4; then compound 2.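

In this assay, putting 4-hydroxy-2,3-dimethylphenyl at this position carries a cost against both carbon-only rings (a 3.9-fold higher number from compound 3 to compound 4 (0.59 log units; beyond the scatter); a 2.5-fold higher number from compound 1 to compound 4 (0.41 log units; beyond the scatter)). The two oxygen-bearing rings are not equal, however (a 2.7-fold lower number from compound 2 to compound 4 (0.44 log units; beyond the scatter)), so a high number does not follow from the presence of oxygen alone, and compound 4 sits in the middle of the series. No available evidence accounts for these differences.

The hydroxy group and the changed arrangement of the methyl groups arrive together in compound 4, so these compounds cannot show how much of its step belongs to each. As far as these compounds go, how the number would respond to an amine or a carboxylic acid on the same ring, or to a longer chain on its oxygen, also remains open.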